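The source may hold more compounds than are shown below. What is called first, only, known or untested is meant among the compounds shown, and "the series" means these compounds.

Measured compounds, with their results in a functional assay on the whole organism (Tail, strain ICR) with Mus musculus as the target, in the tail flick test, with a stated time of 90 min, at a dose of 25 umol/kg by the oral route; a higher number here means a stronger effect of the compound at the dose given, a lower number a weaker effect:

compound 1, `O=C(CN(c1nc(Cl)nc2[nH]cnc12)C1CC1)N[C@@H](CO)C(=O)OCc1ccccc1`, gives 34.5%
compound 2, `O=C(CN(c1nc(Cl)nc2[nH]cnc12)C1CC1)NCC(=O)OCc1ccccc1`, gives 27.2%
compound 3, `NCCCC[C@H](NC(=O)CN(c1nc(Cl)nc2[nH]cnc12)C1CC1)C(=O)OCc1ccccc1`, gives 35.3%

Compound 3 holds the highest of the three numbers, but its gap to compound 1, a number 0.8 percentage points higher from compound 1 to compound 3 (within the scatter), and its gap to compound 2, a number 8.1 percentage points higher from compound 2 to compound 3 (within the scatter), both sit within the scatter, so the three compounds are not separated by this assay. The same is true of the step of a number 7.3 percentage points lower from compound 1 to compound 2 (within the scatter). All three differ only in the group on the saturated chain carbon bound to the amide-type nitrogen and the carbonyl carbon, and none of these changes has moved the number beyond the scatter.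

Compound 4, `CC(C)C[C@H](NC(=O)CN(c1nc(Cl)nc2[nH]cnc12)C1CC1)C(=O)OCc1ccccc1`, continues this series: isopropyl in place of 3-aminopropyl on a saturated chain carbon, two bonds along the chain from an amide-type nitrogen and a carbonyl carbon. Cut one bond further out, the change reads 4-aminobutyl to isobutyl. Among the compounds with values here, the steps that bear on it are the two changes at this same place, from compound 1 to compound 3 and from compound 2 to compound 3, each within the scatter. A step within the scatter is therefore expected for compound 4 as well, with no direction preferred: a number 3.3 percentage points lower from compound 3 to compound 4 (within the scatter). Compound 4 is expected to give 32% in this assay, with a range from 21% to 43%.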

Compound 4, a percentage reported as activity, at one dose (the size of the read-out at that dose, not a potency): 15.2%
For compound 4 the middle estimate is 16.8 percentage points above the measured one; the whole stated range lies above it.
By their numbers in this assay, from the lowest: compound 4; then compounds 2, 1 and 3 (each within the scatter of the next).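

Working notes on the chain carbon bound to the amide-type nitrogen and the carbonyl carbon: in the read-out of (this assay), this place does respond to its substituent, since isobutyl is the first group here to move the number beyond the scatter, and compound 4 stands lowest of the four, in all three of its steps (a number 20.1 percentage points lower from compound 3 to compound 4 (beyond the scatter); a number 19.3 percentage points lower from compound 1 to compound 4 (beyond the scatter)). The fall is not confined to the removal of the nitrogen-bearing 4-aminobutyl chain, as isobutyl also gives a lower number than hydrogen at this same place (a number 12 percentage points lower from compound 2 to compound 4 (beyond the scatter)), so the hydrogen, hydroxymethyl and 4-aminobutyl compounds share a level that this group alone leaves. Nothing measured here bears on why isobutyl lowers the number.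

A straight butyl chain would show whether the lower number follows the branching of isobutyl or holds for a hydrocarbon chain of this size in general. As far as these compounds go, a carboxylic acid or a benzyl group at this place remains open, as does any shorter hydrocarbon group such as methyl, so the extent of the fall across hydrocarbon groups is undefined.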